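The compounds below may be only part of what the source reports. "The series", "measured", "known", "first", "only" and "open" are said of these compounds alone.

Of the compounds shown here, three have so far been measured in an assay on Sf21 cells for inhibition of mitogen-activated protein kinase kinase kinase 13 (Homo sapiens), read by HTRF, with a stated time of 1.5 h; a higher number here means a weaker inhibitor, a lower number a stronger inhibitor. Compound 1 `Nc1ncc(-c2cc(N3C[C@@H]4C[C@H]3CO4)nc(N3CC4CC3C4)n2)nc1OC(F)F` gives 7 nM in this assay. Compound 2 `CSc1cc(-c2cnc(N)c(OC(F)F)n2)nc(N2C[C@@H]3C[C@H]2CO3)n1` gives 45 nM in this assay, and compound 3 `Nc1ncc(-c2cc(C3CC3)cc(N3C[C@@H]4C[C@H]3CO4)n2)nc1OC(F)F` gives 75 nM in this assay. Compound 1 thus stands at the lowest number of the three; its gap to compound 2 and its larger gap to compound 3 both lie beyond the usual scatter, so compound 1 is the strongest inhibitor of the set. Going by the values given here, no two of these measured compounds differ in only one place, so no single step between measured compounds can be read off.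

Among the compounds with values here, compound 4 `Nc1ncc(-c2cc(N3C[C@@H]4C[C@H]3CO4)nc(N3CC4CC3C4)n2)nc1C(F)(F)F` has not yet been measured in this assay. trifluoromethyl in place of difluoromethoxy on an aromatic carbon marks its single difference from compound 1: the difluoromethoxy group gives way to trifluoromethyl on an aromatic carbon of a six-membered aromatic ring with 2 nitrogen, next to the ring nitrogen. Within the data shown here, nothing among the measured compounds tests this exchange, since compounds 2 and 3 keep the difluoromethoxy group and vary elsewhere. The exchange is expected to cost little, with a step of a 1.7-fold higher number from compound 1 to compound 4 (0.23 log units; within the scatter) leaning slightly toward a weaker inhibitor, possibly within the scatter. For compound 4 the estimate is 12 nM, within a range from 4 nM to 40 nM once measured.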

Compound 4, half-maximal inhibitory concentration: 149 nM
Estimate against measurement, compound 4: 12-fold (1.09 log units) below, outside the stated range (above it).
By their numbers in this assay, from the lowest: compound 1; then compounds 2, 3 and 4 (each within the scatter of the next, the first and the last beyond it).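

In this assay, the exchange of difluoromethoxy for trifluoromethyl on this aromatic carbon, ortho to an amino group, gives a 21-fold higher number from compound 1 to compound 4 (1.33 log units; beyond the scatter), a large step that shows this position is far from indifferent to what it carries. Going by these compounds alone, compounds 1, 2 and 3 all keep the difluoromethoxy group, so they could say nothing about this place; this step is the first reading of it, and it shows that two groups with the same heavy-atom count are not interchangeable here. The exchange removes the oxygen and its hydrogen-bond acceptor and brings in a third fluorine, but no measurement at hand bears on why the number moves so far.

The compounds shown leave open whether the oxygen or the fluorine count matters more, a question that a trifluoromethoxy group, which holds both the oxygen and three fluorines, or a plain methoxy group at the same place could help to separate. They also leave open whether a step of this size would hold beside the other groups found in compounds 2 and 3.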